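From ethoxycarbonyl to bromo: estimating compound 4

A few compounds are considered here, and "the series" means these few. Any claim that something is new, unique, unknown or untested is made for them only; others in the source may bear on it.

In a physicochemical assay for lipophilicity, read by HPLC, in phosphate buffer, measured as octanol-water partition, with stated times of 30 min and 48 h, at pH 7.4 (on this read-out higher numbers stand for higher lipophilicity and lower numbers for lower lipophilicity), compound 1 `CCCC(CCC)C(=O)N(C)/N=N/c1ccc(C(=O)OCC)cc1` gives 4.95, and neither of the other two measured numbers exceeds it. Compound 2 `CCCC(CCC)C(=O)N(C)/N=N/c1ccc(C(=O)OC)cc1` gives 4.7, which is a number 0.25 log units lower from compound 1 to compound 2 (within the scatter). Compound 3 `CCCC(CCC)C(=O)N(C)/N=N/c1ccc(Cl)cc1` gives 4.62, which is a number 0.33 log units lower from compound 1 to compound 3 (beyond the scatter). Compound 4 `CCCC(CCC)C(=O)N(C)/N=N/c1ccc(Br)cc1` has not been measured. It differs from compound 1 as follows: bromo in place of ethoxycarbonyl on an aromatic carbon. The closest measured change is chloro in place of ethoxycarbonyl, seen in a number 0.33 log units lower from compound 1 to compound 3 (beyond the scatter). The swap of chloro in place of methoxycarbonyl gave a number 0.08 log units lower from compound 2 to compound 3 (within the scatter). A small drop in this assay is therefore expected, probably no larger than the scatter: the estimated step is a number 0.20 log units lower from compound 1 to compound 4 (within the scatter). The estimate for compound 4 is 4.75, expected to fall between 4.5 and 5.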

Compound 4, distribution coefficient: 4.81
For compound 4 the middle estimate is 0.06 log units below the measured one, and the stated range covers the measured number.
By their numbers in this assay, from the lowest: compounds 3, 2, 4 and 1 (each within the scatter of the next, the first and the last beyond it).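

In this assay, bromo in place of ethoxycarbonyl on this aromatic carbon gives a number 0.14 log units lower from compound 1 to compound 4 (within the scatter), so a group of 5 heavy atoms with 2 hydrogen-bond acceptors gives way to a single bromine atom with a step inside the scatter. Bromo also stays within the scatter of the chloro and methoxycarbonyl compounds, with a number 0.19 log units higher from compound 3 to compound 4 (within the scatter) and a number 0.11 log units higher from compound 2 to compound 4 (within the scatter). No measurement shown explains these small steps.

The compounds shown leave open how a carboxylic acid or an amine on the same aromatic carbon would read.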